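The source may hold more compounds than are shown below. What is called first, only, known or untested is meant among the compounds shown, and "the series" means these compounds.

Within the data shown here, compound 2 `COc1cccc2c1c(C(=O)/C=C(\O)C(=O)O)cn2Cc1cccc(F)c1F` stands at the lower end of the two numbers so far: in an ADME assay on MT4 cells (Homo sapiens) for cytotoxicity, read by MTT assay (on this read-out higher numbers stand for lower toxicity in this test and lower numbers for higher toxicity in this test), compound 2 gives 17500 nM, while compound 1 `COc1cccc2c1c(C(=O)/C=C(\O)C(=O)O)cn2Cc1cc(F)ccc1F` gives 46200 nM. Among the measured compounds shown here, the single measured step, a 2.6-fold lower number from compound 1 to compound 2 (0.42 log units; beyond the scatter), bears on the present change, since it too altered the fluorine pattern on the same ring. Compound 3 `COc1cccc2c1c(C(=O)/C=C(\O)C(=O)O)cn2Cc1ccc(F)cc1` differs by 4-fluorophenyl in place of 2,3-difluorophenyl on a saturated chain carbon bound to an aromatic nitrogen. Given the size of that earlier step, a modest move in this assay is expected, so a step of a 1.7-fold higher number from compound 2 to compound 3 (0.23 log units; within the scatter) toward higher numbers is estimated. Compound 3 is expected at 30000 nM, within the range 12000 nM to 75000 nM.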

Compound 3, half-maximal cytotoxic concentration: 41100 nM
Beside the measured number, compound 3's estimate is 1.4-fold (0.14 log units) below it; measured number inside the range.
By their numbers in this assay, from the lowest: compound 2; then compounds 3 and 1 (each within the scatter of the next).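

On a saturated chain carbon bound to an aromatic nitrogen, the ring pattern separates compounds in this assay only for 2,3-difluorophenyl so far: a 2.3-fold higher number from compound 2 to compound 3 (0.37 log units; beyond the scatter), while a 1.1-fold lower number from compound 1 to compound 3 (0.05 log units; within the scatter). Thus 4-fluorophenyl and 2,5-difluorophenyl cannot be told apart here, and compound 2 alone stands apart from both. Nothing available explains this separation. 

Open, from the compounds shown here alone, is whether an unsubstituted phenyl or a 3-fluorophenyl at this place would fall with compound 2 or with compounds 1 and 3. Going by these compounds, a non-aromatic group such as cyclohexyl also remains open.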